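The compounds below may be only part of what the source reports. "The series", "measured", "known", "first", "only" and "open" are said of these compounds alone.

Working notes on the series.

Compound 2, `CCCC[C@H](NC(=O)[C@H](CCCCN)NC(=O)[C@H](CCCNC(=N)N)NC(=O)c1ccc(/C=C2\SC(=S)N(Cc3ccc(OC)cc3)C2=O)cc1)C(N)=O`, gives in an ADME assay for permeability, using PAMPA (a lower number here means that the compound crosses the layer more slowly, a higher number that the compound crosses the layer faster), a value of 0.6 10^-6 cm/s. Among the compounds with values here, this is the lowest of the two numbers measured so far; its nearest neighbour is compound 1, `CCCC[C@H](NC(=O)[C@H](CCCCN)NC(=O)[C@H](CCCNC(=N)N)NC(=O)c1ccc(/C=C2\SC(=S)N(c3ccc(Cl)cc3)C2=O)cc1)C(N)=O`, which gives 1.02 10^-6 cm/s in this assay. Within the data shown here, the one step measured, a 1.7-fold lower number from compound 1 to compound 2 (0.23 log units; within the scatter), concerns a swap of the group on the amide-type nitrogen in the ring.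

Compound 3, `C=CCN1C(=O)/C(=C/c2ccc(C(=O)N[C@@H](CCCNC(=N)N)C(=O)N[C@@H](CCCCN)C(=O)N[C@@H](CCCC)C(N)=O)cc2)SC1=S`, differs from compound 2 at the same region of the shared core: vinyl in place of 4-methoxyphenyl on a saturated chain carbon bound to an amide-type nitrogen in a ring. Among the measured compounds shown here, the only measured step that bears on a change at this position is a 1.7-fold lower number from compound 1 to compound 2 (0.23 log units; within the scatter), which stayed within the scatter despite a sizeable exchange of groups. Given that precedent, no step beyond the scatter is expected from compound 2 to compound 3, though the direction, if any, is expected to follow the downward drift seen there.

Compound 3 is therefore estimated at 0.55 10^-6 cm/s in this assay, with a range from 0.25 10^-6 cm/s to 1.3 10^-6 cm/s, corresponding to an expected step of a 1.1-fold lower number from compound 2 to compound 3 (0.04 log units; within the scatter).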

Compound 3, apparent permeability: 0.42 10^-6 cm/s
The estimate for compound 3 lay 1.3-fold (0.12 log units) above the measured number; measured number inside the range.
By their numbers in this assay, from the lowest: compounds 3, 2 and 1 (each within the scatter of the next, the first and the last beyond it).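

In this assay, going from 4-methoxybenzyl to allyl on the amide-type nitrogen in the ring removes the six-membered aromatic ring and gives a 1.4-fold lower number from compound 2 to compound 3 (0.15 log units; within the scatter), so even this loss of the ring does not carry the number beyond the scatter. Allyl in place of 4-chlorophenyl at the same nitrogen gives a 2.4-fold lower number from compound 1 to compound 3 (0.39 log units; beyond the scatter), the only step at this position so far that lies beyond the scatter, and it remains modest. No measurement is at hand that bears on the reason for either step.

The compounds shown leave open how this assay would read with an amine, a carboxylic acid or a longer saturated chain on this nitrogen. They also leave open whether the gap from compound 1 to compound 3 reflects a real trend at this position, as compound 2 lies within the scatter of both and a single step beyond the scatter, from one pair, cannot settle that.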